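Swapping Fluoro for Nitro on an Aryl Styryl Sulfone

The compounds below may be only part of what the source reports. "The series", "measured", "known", "first", "only" and "open" are said of these compounds alone.

Compound 1 `COc1cc(OC)c(/C=C/S(=O)(=O)Cc2cc(OC)c(OC)c(OC)c2)c(OC)c1`: > 20000 nM
Compound 2 `COc1ccc(CS(=O)(=O)/C=C/c2ccc(F)cc2)cc1`: 2500 nM

In a functional assay on H157 cells (Homo sapiens) for antiproliferative activity, read by trypan blue exclusion (on this read-out lower numbers stand for stronger inhibition and higher numbers for weaker inhibition), compound 2 gives 2500 nM, the only actual number among the two results shown. Compound 1 gives > 20000 nM, which is a limit of the assay rather than a number (the limit of > 20000 nM in this assay, at which 1 of the 2 values shown sits). Compound 3 `COc1ccc(CS(=O)(=O)/C=C/c2ccc([N+](=O)[O-])cc2)cc1` differs from compound 2 by nitro in place of fluoro on an aromatic carbon. Among the measured compounds shown here, no measured pair of compounds differing in one place is available, so the size of this step has no direct precedent within these data. The expectation is a shift no larger than the usual scatter of repeated measurements, in either direction. Compound 3 is therefore expected to give about 2000 nM, with a plausible range from 600 nM to 7000 nM. The estimated step from compound 2 to compound 3 is a 1.3-fold lower number from compound 2 to compound 3 (0.10 log units; within the scatter).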

Compound 3, half-maximal inhibitory concentration: 7500 nM
Compound 3: the middle estimate sits 3.8-fold (0.57 log units) below what was measured, outside the stated range (above it).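

In this assay, the aromatic carbon para to a large group turns out to respond to what it carries: nitro in place of fluoro brings a 3.0-fold higher number from compound 2 to compound 3 (0.48 log units; beyond the scatter), which means weaker inhibition. Among the compounds shown here, this is the first direct measure of a single change, and it shows that the larger nitro group, though it costs activity here, still leaves compound 3 with an actual number rather than an assay limit. Nothing in the data shown explains why the step goes in this direction.

The compounds shown leave open whether an amine, a chlorine atom or a plain hydrogen on this carbon would give stronger or weaker inhibition than fluoro. With a single step at this position, they also leave open whether any trend runs across such groups.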